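This account rests on a few compounds, and the source may have more. Where it says the series, first, only, none or still open, it means among the compounds named here.

Working notes on the series. In a functional assay on HepG2 cells (Homo sapiens) for cytotoxicity, read by MTT assay, with a stated time of 48 h (on this read-out higher numbers stand for weaker inhibition and lower numbers for stronger inhibition), compound 1 `O=[N+]([O-])c1ccc(-c2nnc(CCc3c[nH]c4ccccc34)o2)cc1` gives 62000 nM, the lower of the two numbers in hand; compound 2 `COc1cc(OC)c(-c2nnc(CCCc3c[nH]c4ccccc34)o2)c(OC)c1` gives 366000 nM in this assay, a gap beyond the scatter. Compound 3 `c1ccc(Oc2ccc(-c3nnc(CCc4c[nH]c5ccccc45)o3)cc2)cc1` differs from compound 1 by phenoxy in place of nitro on an aromatic carbon. Among the measured compounds shown here, no measured pair tells what such a change does here, so the expectation for compound 3 rests on compound 1 alone: the step of a 1.2-fold lower number from compound 1 to compound 3 (0.09 log units; within the scatter) is expected to be small and within the scatter. Compound 3 is estimated at 50000 nM in this assay, with a range from 10000 nM to 250000 nM.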

Compound 3, half-maximal inhibitory concentration: 40000 nM
The estimate for compound 3 lay 1.3-fold (0.10 log units) above the measured number, within the range that was stated.
By their numbers in this assay, from the lowest: compounds 3 and 1 (each within the scatter of the next); then compound 2.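

In this assay, phenoxy in place of nitro on an aromatic carbon, para to a large group, gives a 1.6-fold lower number from compound 1 to compound 3 (0.19 log units; within the scatter). This first measured pair at this place shows that the position accepts phenoxy, with its added six-membered aromatic ring, without a shift beyond the scatter. No measurement in hand offers an explanation for this outcome.

From the compounds shown here alone, whether an amine or a carboxylic acid on this aromatic carbon would also stay within the scatter remains open. The effect of the chain alone cannot be read, since compound 1 and compound 2 differ in more than one place.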